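Cytotoxicity of a 2-hydroxyphenyl aminopyrimidine series

This account rests on a few compounds, and the source may have more. Where it says the series, first, only, none or still open, it means among the compounds named here.

Compound 1: `Nc1nc(-c2ccc(F)cc2)cc(-c2ccccc2O)n1` — 67500 nM
Compound 2: `COc1ccc(-c2cc(-c3ccccc3O)nc(N)n2)cc1` — 92200 nM
Compound 3: `Cc1cccc(-c2cc(-c3ccccc3O)nc(N)n2)c1` — not yet measured

Of the compounds shown here, two have been read in an ADME assay on MT4 cells (Homo sapiens) for cytotoxicity, read by MTT assay, with a stated time of 5 days; on this read-out lower numbers stand for higher toxicity in this test and higher numbers for lower toxicity in this test. Compound 1 gives 67500 nM, the lowest of the two numbers, and its nearest neighbour is compound 2 with 92200 nM. Among the compounds with values here, the only step between measured compounds, a 1.4-fold higher number from compound 1 to compound 2 (0.14 log units; within the scatter), replaces fluoro with methoxy on an aromatic carbon and does not move the number beyond the scatter.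

Compound 3 is the next compound, and it differs from compound 1 by 3-methylphenyl in place of 4-fluorophenyl on an aromatic carbon. Within the data shown here, the one step that bears on it, a 1.4-fold higher number from compound 1 to compound 2 (0.14 log units; within the scatter), shows that changing the substituent on the same aromatic carbon left the reading within the scatter. On that basis the step from compound 1 to compound 3 is also expected to stay within the scatter, with no clear direction, as expressed by a 1.0-fold higher number from compound 1 to compound 3 (0.02 log units; within the scatter). Compound 3 is therefore expected to give 70000 nM in this assay, with a likely range from 30000 nM to 160000 nM.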

Compound 3, half-maximal cytotoxic concentration: 13000 nM
Beside the measured number, compound 3's estimate is 5.4-fold (0.73 log units) above it; measured number outside the range, below it.
By their numbers in this assay, from the lowest: compound 3; then compounds 1 and 2 (each within the scatter of the next).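

In this assay, the exchange of 4-fluorophenyl for 3-methylphenyl on the aromatic carbon of the shared core gives a 5.2-fold lower number from compound 1 to compound 3 (0.72 log units; beyond the scatter), so a change at this position can move the number beyond the scatter and towards higher toxicity in this test, whereas the earlier change on the same aryl group gave only a 1.4-fold higher number from compound 1 to compound 2 (0.14 log units; within the scatter). The leaving and entering groups have the same count of heavy atoms, the same six-membered aromatic ring of carbon only, and no hydrogen-bond donors or acceptors, so these counts do not separate the two groups even though their numbers differ beyond the scatter. No measurement among those available gives a reason for this difference.

Compound 3 differs from compound 1 both in the substituent and in where it stands on the phenyl ring, so the compounds shown do not tell whether the methyl group itself or its placement goes with the lower number. As far as these compounds go, it also remains open how this position would read with a phenyl ring carrying an amine or a carboxylic acid, or with a longer chain such as propyl on that ring.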